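A few compounds are considered here, and "the series" means these few. Any claim that something is new, unique, unknown or untested is made for them only; others in the source may bear on it.

Among the measured compounds shown here, compound 1, with the structure `COc1cc([C@@H]2Oc3cc(/C=C/C=O)cc(OC)c3O[C@H]2CO)cc(OC)c1O`, gives 48700 nM in a functional assay on cells (Neutrophil, Homo sapiens) for inhibition (a higher number here means a weaker inhibitor, a lower number a stronger inhibitor), the higher of the two numbers measured so far. For the measured compounds named here, its only measured neighbour, compound 2 `COc1cc([C@@H]2Oc3cc(/C=C/C=O)ccc3O[C@H]2CO)cc(OC)c1O`, gives 26900 nM; the step of a 1.8-fold lower number from compound 1 to compound 2 (0.26 log units; within the scatter) falls within the scatter of repeated measurements, so the two values cannot be ordered.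

Compound 3 `COc1cc([C@@H]2Oc3cc(/C=C/C=O)cc(OC)c3O[C@H]2CO)ccc1O` has not been measured. It differs from compound 1 by hydrogen in place of methoxy on an aromatic carbon.

Going by the values given here, the only measured step that bears on this change, a 1.8-fold lower number from compound 1 to compound 2 (0.26 log units; within the scatter), also put hydrogen in place of methoxy on an aromatic carbon and stayed within the scatter. On that basis the step from compound 1 to compound 3 is expected to be small, with no clear direction: the estimated step is a 1.2-fold lower number from compound 1 to compound 3 (0.09 log units; within the scatter). Compound 3 is therefore expected to give about 40000 nM, within a range from 15000 nM to 110000 nM.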

Compound 3, half-maximal inhibitory concentration: > 50000 nM
Compound 3 was reported as a limit; the forecaster's own chance of this, stated with the estimate: 15%; middle value at least 1.2-fold (0.09 log units) from the limit.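

In this assay compound 3 gives > 50000 nM, which is a limit of the assay and not a number. Hydrogen in place of the methoxy ortho to a hydroxy group gives an at least 1.0-fold higher number from compound 1 to compound 3 (0.01 log units; that floor lies within the scatter), so this second position, like the one changed in compound 2, shows no step beyond the scatter, but here the step is open only towards a higher number and could be larger than its floor. Unlike compound 2, compound 3 therefore fixes only one side of the change: the limit of > 50000 nM in this assay, at which 1 of the 3 values shown sits.

From the compounds shown here alone, how far the true value of compound 3 lies past that limit remains open. So does how this position would read with a larger ether such as ethoxy, with fluorine, or with an amine in place of the methoxy.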